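Cyclopropane configuration swap in a diazabicyclic pyridine series

The source may hold more compounds than are shown below. What is called first, only, known or untested is meant among the compounds shown, and "the series" means these compounds.

Compound 1 `COCC[C@H]1C[C@@H]1c1cncc(N2C[C@@H]3C[C@H]2CN3)c1` gives 3.1 nM in an assay on a protein complex for displacement of a labelled ligand from Neuronal acetylcholine receptor; alpha2/beta2 (Rattus norvegicus), read by scintillation counting (a higher number here means a weaker inhibitor, a lower number a stronger inhibitor), the higher of the two numbers in hand; compound 2 `c1cncc(N2CC3CC2CN3)c1` gives 0.3 nM in this assay. Compound 3 `COCC[C@@H]1C[C@H]1c1cncc(N2C[C@@H]3C[C@H]2CN3)c1` differs from compound 1 in that (the two compounds have the same atoms and bonds and differ only in configuration as drawn: 2 of 4 stereo elements differ; a stereocentre at a saturated ring carbon is drawn R in compound 1 and S in compound 3; a stereocentre at a saturated ring carbon is drawn S in compound 1 and R in compound 3). Within the data shown here, no pair in hand shows what a change of configuration alone does here, so the direction of the step is open; a step not beyond the scatter, with some chance of a modest shift either way, is the working expectation. Compound 3 is therefore estimated at 4 nM in this assay, range 1 nM to 15 nM, a step of a 1.3-fold higher number from compound 1 to compound 3 (0.11 log units; within the scatter).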

Compound 3, inhibition constant: 43.1 nM
Beside the measured number, compound 3's estimate is 11-fold (1.03 log units) below it; the whole stated range lies below it.
By their numbers in this assay, from the lowest: compound 2; then compound 1; then compound 3.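

In this assay, the arrangement at the two saturated ring carbons alone matters a great deal here: a 14-fold higher number from compound 1 to compound 3 (1.14 log units; beyond the scatter). The arrangement drawn in compound 1 is the favoured one of this pair. The step can be laid to that swap of the two stereocentres alone, because nothing else changes: the fact that compounds 1 and 3 differ only in the configuration as drawn.

On these data alone, what the remaining arrangements of these two stereocentres would give stays open. So does whether the preference for the arrangement in compound 1 persists when the methoxy end of the chain gives way to an amine or a carboxylic acid.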